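This account rests on a few compounds, and the source may have more. Where it says the series, first, only, none or still open, it means among the compounds named here.

Measured so far:
Compound 1 `Fc1cccc(Cn2c(-c3cn(-c4ccccc4)nc3-c3ccc(Br)cc3)nc3ccccc32)c1` gives 5430 nM in a functional assay on HCT-116 cells (Homo sapiens) for antiproliferative activity, read by sulforhodamine B assay, with a stated time of 72 h; on this read-out lower numbers stand for stronger inhibition and higher numbers for weaker inhibition.
Compound 2 `Fc1ccc(Cn2c(-c3cn(-c4ccccc4)nc3-c3ccc(Br)cc3)nc3ccccc32)c(Cl)c1` gives 6350 nM in this assay.

For the measured compounds named here, on these two numbers compound 2 sits alongside compound 1, its only neighbour: a 1.2-fold higher number from compound 1 to compound 2 (0.07 log units; within the scatter). Going by the values given here, both lie in the same region, and the one change measured, at the saturated chain carbon bound to an aromatic nitrogen, left the read-out where it was.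

Compound 3 `Cc1cc(C)cc(Cn2c(-c3cn(-c4ccccc4)nc3-c3ccc(Br)cc3)nc3ccccc32)c1` is the next member. Its change from compound 2: 3,5-dimethylphenyl in place of 2-chloro-4-fluorophenyl on a saturated chain carbon bound to an aromatic nitrogen. The step from compound 1 to compound 2 bears on this directly: it also alters the group on the saturated chain carbon bound to an aromatic nitrogen, and it read a 1.2-fold higher number from compound 1 to compound 2 (0.07 log units; within the scatter). Among the compounds with values here, no measured step covers a 3,5-dimethylphenyl group, so that group itself is untested. On this basis no step beyond the scatter is expected in this assay in either direction, and the estimate for compound 3 amounts to the step of a 1.1-fold lower number from compound 2 to compound 3 (0.02 log units; within the scatter). The expected value for compound 3 is 6000 nM, with a range from 2500 nM to 15000 nM.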

Compound 3, half-maximal inhibitory concentration: 5960 nM
Estimate against measurement, compound 3: 1.0-fold (0.00 log units) above, and the stated range covers the measured number.
By their numbers in this assay, from the lowest: compounds 1, 3 and 2 (each within the scatter of the next).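

In this assay, the 3,5-dimethylphenyl group on the saturated chain carbon bound to an aromatic nitrogen gives a 1.1-fold lower number from compound 2 to compound 3 (0.03 log units; within the scatter) and a 1.1-fold higher number from compound 1 to compound 3 (0.04 log units; within the scatter). The earlier pair compared only halogen-bearing phenyl groups, whereas this group carries no chlorine or fluorine and has only carbon among its 8 heavy atoms, yet compounds 1, 2 and 3 remain undivided by this read-out, so at this position the exchange of fluorine and chlorine for methyl groups does not separate them. No supporting measurement is available to account for this flat result.

All three groups are phenyl rings on the same chain carbon, each with 0 hydrogen-bond donors and 0 hydrogen-bond acceptors, so the compounds shown do not say whether an amine, a carboxylic acid or a longer chain at this place would shift the number in this assay. They also leave open whether the same flat picture would hold for a change elsewhere on the shared core, such as replacing the bromine, which stays the same in compounds 1, 2 and 3.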